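The source may report more compounds than this note shows. Statements on the series, on what has been measured and on what is new or still open speak of the compounds shown alone.

Working notes on the series. Compound 1 `CC(=O)N1CCC(NC(=O)c2ccncc2Nc2cc(-c3ccc4ccn(C)c4c3)c3nccnc3c2)CC1` gives 18 nM in an assay for inhibition of 6-phosphofructo-2-kinase/fructose-2,6-bisphosphatase 3 (Homo sapiens), read by ADP-Glo, with a stated time of 2 h; on this read-out higher numbers stand for weaker inhibition and lower numbers for stronger inhibition. Compound 2 `CC(=O)N1CCCC(NC(=O)c2ccncc2Nc2cc(-c3ccc4ccn(C)c4c3)c3nccnc3c2)C1` gives 11 nM in this assay. The step of a 1.6-fold lower number from compound 1 to compound 2 (0.21 log units; within the scatter) is the only measured one so far. Compound 2 shows the smaller of the two numbers, but the gap to compound 1 is within the scatter, so no order between them is asserted.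

Compound 3 `CN1CC(NC(=O)c2ccncc2Nc2cc(-c3ccc4ccn(C)c4c3)c3nccnc3c2)C1` is not yet measured in this assay. It differs from compound 2 by 1-methylazetidin-3-yl in place of 1-acetylpiperidin-3-yl on an amide-type nitrogen. Among the measured compounds shown here, the one measured step that touches this position, a 1.6-fold lower number from compound 1 to compound 2 (0.21 log units; within the scatter), exchanged one acetylpiperidinyl isomer for another on the same amide-type nitrogen and stayed within the scatter; no measured pair changes the ring size or removes the acetyl group. The expected step of a 1.8-fold higher number from compound 2 to compound 3 (0.26 log units; within the scatter) is therefore of no settled direction and carries wide uncertainty. Compound 3 is estimated at 20 nM in this assay, with a range from 6 nM to 70 nM.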

Compound 3, half-maximal inhibitory concentration: 30 nM
Beside the measured number, compound 3's estimate is 1.5-fold (0.18 log units) below it; the measured number falls inside the stated range.
By their numbers in this assay, from the lowest: compounds 2, 1 and 3 (each within the scatter of the next, the first and the last beyond it).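

In this assay, among the compounds shown here, the exchange of 1-acetylpiperidin-3-yl for 1-methylazetidin-3-yl on an amide-type nitrogen gives a 2.7-fold higher number from compound 2 to compound 3 (0.44 log units; beyond the scatter) and is the first step at this position beyond the scatter, though a modest one. For the compounds shown here, the same entering group in place of 1-acetylpiperidin-4-yl gives a 1.7-fold higher number from compound 1 to compound 3 (0.22 log units; within the scatter) and stays within the scatter, so only one of the two comparisons shows a difference, and a four-membered ring without an acetyl group is carried at this position with the number still close to that of compound 1. Nothing available bears on the cause of the step.

The compounds shown leave open how much of the step belongs to the ring size and how much to methyl in place of acetyl on the ring nitrogen. A 1-methylpiperidin-3-yl group or a 1-acetylazetidin-3-yl group on the same amide-type nitrogen would separate the two.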